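This account rests on a few compounds, and the source may have more. Where it says the series, first, only, none or still open, it means among the compounds named here.

In an ADME assay on the whole organism (strain 129/SvEvBrd x C57BL/6) for metabolic stability, with Mus musculus as the target (on this read-out higher numbers stand for a longer-lived compound and lower numbers for a shorter-lived compound), compound 1 `CN(C)C(=O)c1nc([C@@H](O)[C@H](O)[C@H](O)CO)c[nH]1` gives 4 h and compound 2 `OC[C@@H](O)[C@@H](O)[C@H](O)c1c[nH]c(-c2ncccn2)n1` gives 2.4 h. Within the data shown here, these are the only two numbers available, and compound 2 stands within the scatter of compound 1, so the two cannot be told apart. Compound 3 `OC[C@@H](O)[C@@H](O)[C@H](O)c1c[nH]c(-c2cnccn2)n1` keeps the core of compound 2 and alters one group: pyrazin-2-yl in place of pyrimidin-2-yl on an aromatic carbon. Pyrazin-2-yl takes the place of pyrimidin-2-yl on an aromatic carbon, with the same atoms joined differently. Among the measured compounds shown here, the only measured step at this place, a 1.7-fold lower number from compound 1 to compound 2 (0.22 log units; within the scatter), exchanged dimethylcarbamoyl for pyrimidin-2-yl and stayed within the scatter. For the measured compounds named here, no measured step exchanges pyrimidin-2-yl for pyrazin-2-yl, so the data give no direction, and no change beyond the scatter is expected in this assay. The expected step is a 1.0-fold higher number from compound 2 to compound 3 (0.02 log units; within the scatter). Compound 3 is estimated at 2.5 h, with an expected range of 1.2 h to 5 h.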

Compound 3, half-life: 1.9 h
Beside the measured number, compound 3's estimate is 1.3-fold (0.12 log units) above it, within the range that was stated.
By their numbers in this assay, from the lowest: compounds 3, 2 and 1 (each within the scatter of the next, the first and the last beyond it).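

At this place on the five-membered aromatic ring, pyrazin-2-yl and pyrimidin-2-yl, the same atoms joined differently, cannot be told apart in this assay (a 1.3-fold lower number from compound 2 to compound 3 (0.10 log units; within the scatter)). Pyrazin-2-yl in place of dimethylcarbamoyl gives the only step here that lies beyond the scatter (a 2.1-fold lower number from compound 1 to compound 3 (0.32 log units; beyond the scatter)), though it is modest, while compound 2 with pyrimidin-2-yl stays within the scatter of both compound 1 and compound 3. No measurement at hand accounts for either step.

As far as these compounds go, whether a phenyl ring, a carboxylic acid or a primary amide at this place would separate further from dimethylcarbamoyl remains open. The group of 8 heavy atoms is the same throughout, so the compounds shown say nothing about a shorter chain there.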